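Removing a ring methyl from a second enaminone core

A few compounds are considered here, and "the series" means these few. Any claim that something is new, unique, unknown or untested is made for them only; others in the source may bear on it.

Compound 1 `COc1ccc2nc(-c3ccc(N/C=C\C(=O)c4ccc(OC)c(O)c4)c(C)c3)sc2c1`, in a functional assay on A549 cells (Homo sapiens) for antiproliferative activity, read by sulforhodamine B assay, with a stated time of 48 h (on this read-out higher numbers stand for weaker inhibition and lower numbers for stronger inhibition), compound 1 gives 18000 nM.
Compound 2 `COc1ccc2nc(-c3ccc(N/C=C\C(=O)c4ccc(OC)c(O)c4)cc3)sc2c1`, in this assay compound 2 gives 12800 nM.
Compound 3 `COc1cc(OC)c2sc(-c3ccc(N/C=C\C(=O)c4cc(OC)c(OC)c(OC)c4)c(C)c3)nc2c1`, in this assay compound 3 gives 14400 nM.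

Compounds 1 and 2 share a core and differ by hydrogen in place of methyl on an aromatic carbon. That change gave a 1.4-fold lower number from compound 1 to compound 2 (0.15 log units; within the scatter). Compound 3 carries a different core; the difference between the two cores is not broken down here, and the values of compound 3 and compound 2 lie close to each other.

Compound 4 `COc1cc(OC)c2sc(-c3ccc(N/C=C\C(=O)c4cc(OC)c(OC)c(OC)c4)cc3)nc2c1` is not yet measured. It differs from compound 3 by hydrogen in place of methyl on an aromatic carbon, the same change as from compound 1 to compound 2. Because the earlier step was a 1.4-fold lower number from compound 1 to compound 2 (0.15 log units; within the scatter), the step to compound 4 is expected to be about as small, a 1.3-fold lower number from compound 3 to compound 4 (0.12 log units; within the scatter). In this assay compound 4 is therefore estimated at 11000 nM, with a likely range from 5000 nM to 25000 nM.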

Compound 4, half-maximal inhibitory concentration: 21800 nM
Compound 4: the middle estimate sits 2.0-fold (0.30 log units) below what was measured; measured number inside the range.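

Replacing the methyl with hydrogen on the core of compound 3 gave a 1.5-fold higher number from compound 3 to compound 4 (0.18 log units; within the scatter) in this assay. Set beside the same change on the other core, the two steps cannot be told apart: the same change on two cores in this assay, a 1.4-fold lower number (0.15 log units; within the scatter) from compound 1 to compound 2 and a 1.5-fold higher number (0.18 log units; within the scatter) from compound 3 to compound 4, 2.1-fold (0.33 log units) apart, within the scatter of two such steps. The change therefore stayed within the scatter on both cores, which shows that its small size carried over between these two cores, but it shows no reliable direction and says nothing about any other core.

The compounds shown leave open whether a different group in this place, such as a chlorine, a methoxy group or a longer chain, would move the number beyond the scatter. They also leave open how the change would behave in any other assay.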